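Removing the Phenyl from Compound 1

The compounds below may be only part of what the source reports. "The series", "measured", "known", "first", "only" and "open" are said of these compounds alone.

Compound 1 `c1ccc(-c2nc(-c3c[nH]c4ccccc34)co2)cc1` stands, in a functional assay on MIA PaCa-2 cells (Homo sapiens) for cytotoxicity, read by MTT assay, with a stated time of 48 h (a higher number here means a weaker inhibitor, a lower number a stronger inhibitor), at the highest of the two numbers measured here: compound 1 gives 113000 nM, and its nearest neighbour is compound 2 `COc1ccc(-c2nc(-c3c[nH]c4ccccc34)co2)cc1`, which in this assay gives 35000 nM. Within the data shown here, that step, a 3.2-fold lower number from compound 1 to compound 2 (0.51 log units; beyond the scatter), is the only measured step in the set, and it concerns a methoxy placed on the very phenyl that compound 3 `c1ccc2c(-c3cocn3)c[nH]c2c1` does not carry at all. The change from compound 1 to compound 3 is hydrogen in place of phenyl on an aromatic carbon. Among the measured compounds shown here, no measured pair shows what taking the phenyl away does; the step from compound 1 to compound 2 shows only that a methoxy on that phenyl gives a lower number. On that slender basis the expectation is that the step of a 1.9-fold higher number from compound 1 to compound 3 (0.29 log units; within the scatter) runs towards a higher number, with a real chance that this assay reports only a limit rather than a figure. The estimate for compound 3 is therefore 220000 nM, within a range from 60000 nM to 700000 nM.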

Compound 3, half-maximal inhibitory concentration: 103000 nM
Compound 3: middle estimate off by 2.1-fold (0.33 log units), on the high side; measured number inside the range.
By their numbers in this assay, from the lowest: compound 2; then compounds 3 and 1 (each within the scatter of the next).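

Hydrogen in place of phenyl on this aromatic carbon, next to the ring nitrogen and next to the ring oxygen, gives a 1.1-fold lower number from compound 1 to compound 3 (0.04 log units; within the scatter) in this assay, so the two compounds cannot be told apart in this read-out. Among these compounds, the phenyl as a whole can therefore go without a change that stands clear of the scatter, whereas the methoxy placed on that same phenyl gives a 3.2-fold lower number from compound 1 to compound 2 (0.51 log units; beyond the scatter) and remains the only step here that lies beyond it. What a substituent on the phenyl does at this position and what the phenyl itself does are thus two separate observations, and nothing among the data shown offers an explanation for either of them.

The compounds shown leave open what a different group on this carbon would do, such as an amine, a carboxylic acid or a longer alkyl chain, since hydrogen and phenyl are the only two compared here. They also leave open whether the methoxy step depends on the phenyl that carries it, or whether a methoxy set directly on this carbon would give a similar number.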